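Swapping the Ring Group on the Triazole Nitrogen

The source may report more compounds than this note shows. Statements on the series, on what has been measured and on what is new or still open speak of the compounds shown alone.

Measured compounds:
- Compound 1 `N#Cc1ccc(Cn2cc(C[C@H](O)COCCOC[C@@H](O)Cc3ccc(-c4ccccc4)cc3)nn2)cc1`: 7700 nM
- Compound 2 `O[C@H](COCCOC[C@@H](O)Cc1cn(-c2ccc3c(c2)OCCO3)nn1)Cc1ccc(-c2ccccc2)cc1`: 6400 nM
- Compound 3 `O[C@H](COCCOC[C@@H](O)Cc1cn(Cc2ccc3ccccc3c2)nn1)Cc1ccc(-c2ccccc2)cc1`: 12100 nM

These three share one core and differ only in the group on an aromatic nitrogen of the five-membered ring with three nitrogens. In a functional assay on SGC-7901 cells (Homo sapiens) for inhibition, read by MTT assay, with a stated time of 72 h (a higher number here means a weaker inhibitor of growth, a lower number a stronger inhibitor of growth), compound 3 gives 12100 nM, the highest of the three numbers, yet the steps of a 1.6-fold higher number from compound 1 to compound 3 (0.20 log units; within the scatter) and a 1.9-fold higher number from compound 2 to compound 3 (0.28 log units; within the scatter) both sit within the scatter, as does a 1.2-fold lower number from compound 1 to compound 2 (0.08 log units; within the scatter). So far, changing this group has not moved the number beyond the noise.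

Compound 4 `O=c1[nH]c2ccc(-n3cc(C[C@H](O)COCCOC[C@@H](O)Cc4ccc(-c5ccccc5)cc4)nn3)cc2s1` carries the same change in kind: a group of 10 heavy atoms (7 carbon, 1 nitrogen, 1 oxygen, 1 sulfur; one five-membered aromatic ring with 2 hetero atoms, one six-membered aromatic ring of carbon only) in place of a group of 11 heavy atoms (11 carbon; 2 six-membered aromatic rings of carbon only), on an aromatic nitrogen. For the measured compounds named here, the three measured steps, all within the scatter, are the only guide, and they point to a small step at most in this assay, with no clear direction. Compound 4 is therefore expected to land near the measured cluster, a 1.4-fold lower number from compound 3 to compound 4 (0.15 log units; within the scatter), at an estimated 8500 nM with a range from 3500 nM to 20000 nM.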

Compound 4, concentration for 50% growth inhibition: 10500 nM
Estimate against measurement, compound 4: 1.2-fold (0.09 log units) below; the range from low to high includes it.
By their numbers in this assay, from the lowest: compounds 2, 1, 4 and 3 (each within the scatter of the next).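

In this assay, the group entering in compound 4 brings a five-membered aromatic ring with 2 hetero atoms, one of them sulfur, plus a hydrogen-bond donor and hydrogen-bond acceptors, where (naphthalen-2-yl)methyl has neither, yet it gives only a 1.2-fold lower number from compound 3 to compound 4 (0.06 log units; within the scatter). The other two comparisons are also small, a 1.6-fold higher number from compound 2 to compound 4 (0.22 log units; within the scatter) and a 1.4-fold higher number from compound 1 to compound 4 (0.13 log units; within the scatter), so on this aromatic nitrogen even a group of a different make-up stays within the scatter of the other three. No measurement shown here explains this flat result.

Every group shown contains a six-membered aromatic ring of carbon only, so the effect of a small methyl, or of a short chain ending in an amine or a carboxylic acid, remains open. On these data alone, the rest of the shared core is the same throughout, so what a change there would do also remains open.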